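A few compounds are considered here, and "the series" means these few. Any claim that something is new, unique, unknown or untested is made for them only; others in the source may bear on it.

In a functional assay on T47D cells (Homo sapiens) for inhibition, read by CCK-8 assay, with a stated time of 72 h, tested at 1 uM (on this read-out lower numbers stand for less inhibition of growth and higher numbers for more inhibition of growth at the one concentration tested), compound 1 (`CN(C)C(=O)c1cc2cnc(Nc3ccc(NC(=O)C4(C(=O)Nc5ccc(F)cc5)CC4)cc3)nc2n1C1CCCC1`) gives 74.7% and stands second highest of the three numbers in hand. Above it compound 3 (`CN(C)C(=O)c1cc2cnc(Nc3ccc(NC(=O)C4(C(=O)Nc5ccccc5F)CC4)cc3)nc2n1C1CCCC1`) gives 85.2%. The lowest number comes from compound 2 (`CN(C)C(=O)c1cc2cnc(Nc3ccc(NC(=O)C4(C(=O)Nc5ccc(Cl)cc5)CC4)cc3)nc2n1C1CCCC1`), which gives 22.8% on the same read-out.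

The next change leads to compound 4 (`CN(C)C(=O)c1cc2cnc(Nc3ccc(NC(=O)C4(C(=O)Nc5ccc(F)cc5)CC4)cc3F)nc2n1C1CCCC1`) and is fluoro in place of hydrogen on an aromatic carbon. For the measured compounds named here, two measured steps bear on it only indirectly. One is a number 51.9 percentage points lower from compound 1 to compound 2 (beyond the scatter) with chloro in place of fluoro on an aromatic carbon, and the other is a number 10.5 percentage points higher from compound 1 to compound 3 (beyond the scatter) with 2-fluorophenyl in place of 4-fluorophenyl on an amide-type nitrogen. Both alter the aryl group on the amide-type nitrogen, so neither is a direct precedent. Going by the values given here, the series holds no measured step of fluoro in place of hydrogen at this place. The steps do show that one halogen change can move this read-out a little or a lot, so the range has to stay wide.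

The estimated step is a number 4.7 percentage points lower from compound 1 to compound 4 (within the scatter) in this assay, so no clear move beyond the scatter is expected. Compound 4 is expected at 70% with 45% to 88% as the estimated range.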

Compound 4, percent growth inhibition at one concentration: 6.3%
Compound 4: the middle estimate sits 63.7 percentage points above what was measured; the whole stated range lies above it.
By their numbers in this assay, from the lowest: compound 4; then compound 2; then compound 1; then compound 3.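

Fluoro in place of hydrogen on an aromatic carbon, ortho to a large group and meta to a large group, gives a number 68.4 percentage points lower from compound 1 to compound 4 (beyond the scatter) in this assay and removes most of the growth inhibition seen with compound 1 at the one concentration tested. For the compounds shown here, the earlier steps, among them a number 51.9 percentage points lower from compound 1 to compound 2 (beyond the scatter) and a number 10.5 percentage points higher from compound 1 to compound 3 (beyond the scatter), all changed the aryl group on the amide-type nitrogen, so this result is the first to show that the read-out also responds strongly to a change on this other six-membered aromatic ring of carbon only, even when that change adds just one heavy atom. Nothing in hand explains the drop, and no reason for it can be assigned.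

As far as these compounds go, whether the drop belongs to fluoro in particular or to any replacement of hydrogen at this carbon stays open, and a methyl group, a methoxy group or an amine on the same carbon would help separate those two readings. Also open, from the compounds shown here alone, is whether the same fluoro has a similar effect when the amide-type nitrogen carries the 2-fluorophenyl group of compound 3.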